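The source may hold more compounds than are shown below. What is called first, only, known or untested is meant among the compounds shown, and "the series" means these compounds.

For the measured compounds named here, in a functional assay on MCF7 cells (Homo sapiens) for inhibition, with a stated time of 48 h, tested at 30 uM (on this read-out lower numbers stand for less inhibition of growth and higher numbers for more inhibition of growth at the one concentration tested), compound 1 `C=C[C@@](C)(/C=C/c1ccc(OC(C)=O)cc1)CCC=C(C)C` gives 56%, the higher of the two numbers so far, and compound 2 `C=C[C@@](C)(/C=C/c1ccc(OC(=O)CCCCCCCCC)cc1)CCC=C(C)C` gives 12%. Compound 3 `C=C[C@@](C)(/C=C/c1ccc(OC)cc1)CCC=C(C)C` has not yet been measured. Its difference from compound 1 is methyl in place of acetyl on an oxygen on an aromatic ring, which turns acetoxy to methoxy. Going by the values given here, only one measured step bears on this, and only indirectly: a number 44 percentage points lower from compound 1 to compound 2 (beyond the scatter), a large step beyond the scatter, made by placing octyl on a saturated chain carbon bound to a carbonyl carbon. That step shows that changing this group can matter, but it enlarges the group, whereas compound 3 has a smaller one and no carbonyl. Among the compounds with values here, no measured pair shows such a swap, so a step of that size is not expected here, and no step beyond the scatter is the likeliest outcome. The expected change is a number 7 percentage points lower from compound 1 to compound 3 (within the scatter). Compound 3 is therefore estimated at 49% in this assay, with an expected range of 25% to 72%.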

Compound 3, percent growth inhibition at one concentration: 37%
Estimate against measurement, compound 3: 12 percentage points above; low and high end bracket the measured number.
By their numbers in this assay, from the lowest: compound 2; then compound 3; then compound 1.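

In this assay, putting methyl in place of acetyl on the oxygen on the aromatic ring gives a number 19 percentage points lower from compound 1 to compound 3 (beyond the scatter). The earlier pair showed only that a longer chain on the carbonyl can lower the number, whereas this result shows that the number also falls when the carbonyl is removed and the group becomes smaller, although compound 3 at 37% still stands above compound 2 at 12%. No measurement shown here accounts for the drop from acetoxy to methoxy.

The compounds shown leave open what a free hydroxyl or an amine at this position would do to growth inhibition. They also leave open whether an ester of intermediate length, such as butanoyl, would fall between compound 1 and compound 2.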